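Adding a Methylimidazolyl Ring to Compound 3

The source may hold more compounds than are shown below. What is called first, only, known or untested is meant among the compounds shown, and "the series" means these compounds.

Going by the values given here, compound 3 `O=C(Nc1ccc(-n2ccc3c(NC(=O)c4ccccc4)ncnc32)cc1)c1cccc(C(F)(F)F)c1` gives 4700 nM in a functional assay on A375P cells (Homo sapiens) for antiproliferative activity, read by MTT assay, with a stated time of 24 h (a lower number here means a stronger inhibitor, a higher number a weaker inhibitor), the highest of the three numbers measured so far. Compound 1 `O=C(Nc1ccc(-n2ccc3c(NC(=O)c4ccccc4)ncnc32)cc1)c1ccc(Cl)c(C(F)(F)F)c1` gives 2300 nM and compound 2 `O=C(Nc1ccc(-n2ccc3c(NC(=O)c4ccccc4)ncnc32)cc1)c1cc(C(F)(F)F)cc(C(F)(F)F)c1` gives 2000 nM. Each of these carries one group more than compound 3 on the same ring, and removing that group raises the number: a 2.0-fold higher number from compound 1 to compound 3 (0.31 log units; beyond the scatter) and a 2.4-fold higher number from compound 2 to compound 3 (0.37 log units; beyond the scatter). Compound 4 `Cc1cn(-c2cc(C(=O)Nc3ccc(-n4ccc5c(NC(=O)c6ccccc6)ncnc54)cc3)cc(C(F)(F)F)c2)cn1` goes the opposite way, with 4-methyl-1H-imidazol-1-yl in place of hydrogen on an aromatic carbon. Because a 2.0-fold higher number from compound 1 to compound 3 (0.31 log units; beyond the scatter) and a 2.4-fold higher number from compound 2 to compound 3 (0.37 log units; beyond the scatter) both run upward when a group is removed from this ring, the reverse addition in compound 4 is expected to give a modest step downward of roughly the same size: a 2.6-fold lower number from compound 3 to compound 4 (0.42 log units; beyond the scatter). Compound 4 is therefore estimated at 1800 nM, with a range from 500 nM to 6000 nM.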

Compound 4, half-maximal inhibitory concentration: 800 nM
Compound 4: middle estimate off by 2.3-fold (0.35 log units), on the high side; the measured number falls inside the stated range.
By their numbers in this assay, from the lowest: compound 4; then compounds 2 and 1 (each within the scatter of the next); then compound 3.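

In this assay the position meta to a trifluoromethyl group takes a whole five-membered aromatic ring, and 4-methyl-1H-imidazol-1-yl gives a 5.9-fold lower number from compound 3 to compound 4 (0.77 log units; beyond the scatter). The same ring also outdoes the trifluoromethyl group it replaces, with a 2.5-fold lower number from compound 2 to compound 4 (0.40 log units; beyond the scatter), so this position is not limited to small groups. Nothing measured here accounts for this drop in the number. From the compounds shown here alone, whether the methyl on the imidazole ring contributes remains open, as does whether an amine or a carboxylic acid at this position would give a similar number.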